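This account rests on a few compounds, and the source may have more. Where it says the series, first, only, none or still open, it means among the compounds named here.

Compound 1 `O=S(=O)(NCCCCNCc1ccc(Br)cc1)c1cc(C(F)(F)F)cc(C(F)(F)F)c1` gives 2000 nM in a functional assay on HPAC cells (Homo sapiens) for inhibition, read by MTT assay, with a stated time of 72 h; a higher number here means a weaker inhibitor of growth, a lower number a stronger inhibitor of growth.
Compound 2 `CC(C)(C)c1ccc(CNCCCNS(=O)(=O)c2cc(C(F)(F)F)cc(C(F)(F)F)c2)cc1` gives 2300 nM in this assay.
Compound 3 `COc1cccc(CNCCCNS(=O)(=O)c2cc(C(F)(F)F)cc(C(F)(F)F)c2)c1` gives 2400 nM in this assay.

Compound 3 shows the highest of the three numbers, yet both steps leading to it, a 1.2-fold higher number from compound 1 to compound 3 (0.08 log units; within the scatter) and a 1.0-fold higher number from compound 2 to compound 3 (0.02 log units; within the scatter), lie within the scatter, so the three compounds cannot be told apart on these numbers. Compound 4 `O=S(=O)(NCCCNCC1COc2ccccc2O1)c1cc(C(F)(F)F)cc(C(F)(F)F)c1` differs from compound 3 in one place: 2,3-dihydro-1,4-benzodioxin-2-yl in place of 3-methoxyphenyl on a saturated chain carbon bound to an amine nitrogen. The two measured steps that bear on this change, a 1.2-fold higher number from compound 1 to compound 3 (0.08 log units; within the scatter) and a 1.0-fold higher number from compound 2 to compound 3 (0.02 log units; within the scatter), also exchanged the group on the saturated chain carbon bound to an amine nitrogen, and neither moved the number beyond the scatter. Given a 1.2-fold higher number from compound 1 to compound 3 (0.08 log units; within the scatter) and a 1.0-fold higher number from compound 2 to compound 3 (0.02 log units; within the scatter), the step of a 1.0-fold higher number from compound 3 to compound 4 (0.02 log units; within the scatter) is expected to stay within the scatter as well. Compound 4 is therefore estimated at 2500 nM in this assay, with a range from 1200 nM to 5500 nM.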

Compound 4, concentration for 50% growth inhibition: 2700 nM
Compound 4: the middle estimate sits 1.1-fold (0.03 log units) below what was measured, within the range that was stated.
By their numbers in this assay, from the lowest: compounds 1, 2, 3 and 4 (each within the scatter of the next).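

The place on a saturated chain carbon bound to an amine nitrogen now also carries a group with a non-aromatic ring with 2 hetero atoms, and in this assay the exchanges for aromatic groups stay small: a 1.1-fold higher number from compound 3 to compound 4 (0.05 log units; within the scatter) and a 1.2-fold higher number from compound 2 to compound 4 (0.07 log units; within the scatter). This change therefore extends the flat picture beyond the 3-methoxyphenyl and 4-(tert-butyl)phenyl groups. Nothing available explains why the numbers stay level.

Going by these compounds, whether a carboxylic acid, a pyridine ring or a simple cyclohexyl group at this place would move the number beyond the scatter remains open. With no step here beyond the scatter, the compounds shown do not reveal which features of this group matter for growth inhibition, if any do.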